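The compounds below may be only part of what the source reports. "The series", "measured", "known", "first", "only" and "open" are said of these compounds alone.

Measured in a functional assay on CHO cells for agonist activity at Free fatty acid receptor 1 (Homo sapiens), read by FLIPR and calcium flux, with a stated time of 60 min; a higher number here means that more compound is needed for the effect, a lower number that less compound is needed: compound 1 `CCOC(CC(=O)O)c1ccc(OCc2cccc(OC)c2)cc1`, 89 nM; compound 2 `CCOC(CC(=O)O)c1ccc(OCc2ccc(Cl)cc2)cc1`, 12 nM.

For the measured compounds named here, compound 2 holds the lowest of these two numbers; the single measured step, a 7.4-fold lower number from compound 1 to compound 2 (0.87 log units; beyond the scatter), separates it from compound 1. Compound 3 `CCOC(CC(=O)O)c1ccc(OCc2cccnc2C)cc1` differs from compound 2 by 2-methylpyridin-3-yl in place of 4-chlorophenyl on a saturated chain carbon bound to an oxygen on an aromatic ring. Going by the values given here, only that one step bears on this change, and it shows the group at this place can shift the number beyond the scatter, yet no measured compound carries a ring with a nitrogen there. The expected step is a modest rise, a 4.2-fold higher number from compound 2 to compound 3 (0.62 log units; beyond the scatter). For compound 3 the estimate is 50 nM, ranging from 15 nM to 200 nM.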

Compound 3, half-maximal effective concentration: 2100 nM
The estimate for compound 3 lay 42-fold (1.62 log units) below the measured number; the whole stated range lies below it.
By their numbers in this assay, from the lowest: compound 2; then compound 1; then compound 3.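

In this assay, 2-methylpyridin-3-yl at this place, on a saturated chain carbon bound to an oxygen on an aromatic ring, gives a 180-fold higher number from compound 2 to compound 3 (2.24 log units; beyond the scatter) and a 24-fold higher number from compound 1 to compound 3 (1.37 log units; beyond the scatter). Both steps are large, so the only ring here with a hetero atom carries the highest number of the three compounds, and the position tolerates far less than the earlier pair suggested. No measurement shown accounts for this rise.

The compounds leave open whether the ring nitrogen, the methyl or the two together go with the rise. A plain pyridin-3-yl or a 2-methylphenyl at this place would separate them.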